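The source may report more compounds than this note shows. Statements on the series, on what has been measured and on what is new or still open speak of the compounds shown alone.

Three compounds share one core and differ only in the group on the carbonyl carbon of the ring amide. Compound 1 `O=C(C1CCCCC1)N1CCc2nc(C#Cc3ccccc3)sc2C1` carries cyclohexyl there, and in an assay on HEK293 cells for positive allosteric modulation of metabotropic glutamate receptor 5 (Homo sapiens), read by FLIPR, with a stated time of 1 h (a higher number here means that more compound is needed for the effect, a lower number that less compound is needed), compound 1 gives 167 nM. Compound 2 `O=C(C1CCC(F)(F)CC1)N1CCc2nc(C#Cc3ccccc3)sc2C1` carries 4,4-difluorocyclohexyl, and in this assay compound 2 gives 70 nM. Compound 3 `O=C(C1CCOCC1)N1CCc2nc(C#Cc3ccccc3)sc2C1` carries oxan-4-yl, and in this assay compound 3 gives 290 nM, the highest of the three numbers; the two steps that lead there are a 1.7-fold higher number from compound 1 to compound 3 (0.24 log units; within the scatter) and a 4.1-fold higher number from compound 2 to compound 3 (0.62 log units; beyond the scatter), and between the two cyclohexyl compounds the step is a 2.4-fold lower number from compound 1 to compound 2 (0.38 log units; beyond the scatter).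

Compound 4 `Cc1cccc(C(=O)N2CCc3nc(C#Cc4ccccc4)sc3C2)n1` is the next step from compound 3: 6-methylpyridin-2-yl in place of oxan-4-yl on a carbonyl carbon. The measured steps all swap one six-membered non-aromatic ring for another and move the number only modestly; none brings an aromatic ring onto the carbonyl carbon, so they offer only a loose guide here. Compound 4 is therefore expected to sit near compound 3, with the step of a 1.6-fold lower number from compound 3 to compound 4 (0.21 log units; within the scatter) reflecting a mild lowering at most. In this assay compound 4 is estimated at 180 nM, with a plausible range from 40 nM to 800 nM.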

Compound 4, half-maximal effective concentration: 160 nM
For compound 4 the middle estimate is 1.1-fold (0.05 log units) above the measured one; low and high end bracket the measured number.
By their numbers in this assay, from the lowest: compound 2; then compounds 4, 1 and 3 (each within the scatter of the next).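

The place on the carbonyl carbon, whose other neighbour is an amide-type nitrogen in a ring, now proves to accept an aromatic ring as well as the non-aromatic ones: in this assay, the exchange of oxan-4-yl for 6-methylpyridin-2-yl gives a 1.8-fold lower number from compound 3 to compound 4 (0.26 log units; within the scatter) and the exchange of cyclohexyl for it gives a 1.0-fold lower number from compound 1 to compound 4 (0.02 log units; within the scatter) as its step. The new compound therefore cannot be told apart from either of these two, and across these three compounds aromatic against non-aromatic makes no readable difference. The 4,4-difluorocyclohexyl group alone stands apart, with a 2.3-fold higher number from compound 2 to compound 4 (0.36 log units; beyond the scatter) as the step to the new group, so compound 2 now has the lowest number of the four, beyond the scatter from each of the others.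

Nothing offered here says why these groups behave as they do at this place. Still open, on these data alone, is how a plain phenyl, an unsubstituted pyridin-2-yl or an open alkyl chain on the carbonyl carbon would compare, and so what the methyl and the ring nitrogen of 6-methylpyridin-2-yl each contribute.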